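Replacing pyridin-4-yl with 2-fluorophenyl in compound 3

A few compounds are considered here, and "the series" means these few. Any claim that something is new, unique, unknown or untested is made for them only; others in the source may bear on it.

Measured so far in a functional assay on MCF7 cells (Homo sapiens) for cytotoxicity, read by MTT assay and propidium iodide staining, with a stated time of 24 h; on this read-out lower numbers stand for stronger inhibition and higher numbers for weaker inhibition

Compound 1 `CC(C)(C)c1ccc(-c2nnc(SCC(=O)c3ccccc3)o2)cc1` gives 50 nM
Compound 2 `CN(C)c1ccc(-c2nnc(SCC(=O)c3ccccc3)o2)cc1` gives 210 nM
Compound 3 `O=C(CSc1nnc(-c2ccncc2)o1)c1ccccc1` gives 370 nM

Compound 3 at 370 nM cannot be separated from compound 2 at 210 nM given the usual scatter, while compound 1 at 50 nM has a clearly lower number than either.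

The open question is compound 4 `O=C(CSc1nnc(-c2ccccc2F)o1)c1ccccc1` in this assay and how it compares. Reaching it from compound 3 takes one change 2-fluorophenyl in place of pyridin-4-yl on an aromatic carbon in which 2-fluorophenyl replaces pyridin-4-yl on an aromatic carbon.

Among the measured compounds shown here, only one measured step offers guidance, and it is indirect. That step is a 4.2-fold higher number from compound 1 to compound 2 (0.62 log units; beyond the scatter) with dimethylamino in place of tert-butyl on an aromatic carbon. It shows that a single exchange in this series can move the number by a modest amount. For the measured compounds named here, no measured step involves fluorine or removes a ring nitrogen.

Compound 1 (50 nM) and compound 2 (210 nM) both carry a carbon-only aromatic ring on the shared core, so a value for compound 4 within or close to their span is expected. The expected change is modest, an estimated 2.3-fold lower number from compound 3 to compound 4 (0.36 log units; beyond the scatter) and so a lower number. In this assay the estimated value for compound 4 is 160 nM with an expected range from 50 nM to 450 nM and the wide range reflects how little evidence exists.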

Compound 4, half-maximal inhibitory concentration: 260 nM
For compound 4 the middle estimate is 1.6-fold (0.21 log units) below the measured one; the measured number falls inside the stated range.
By their numbers in this assay, from the lowest: compound 1; then compounds 2, 4 and 3 (each within the scatter of the next).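

In this assay, replacing pyridin-4-yl with 2-fluorophenyl on this aromatic carbon of the shared core gives a 1.4-fold lower number from compound 3 to compound 4 (0.15 log units; within the scatter), so the two groups cannot be told apart on this read-out. Among the compounds shown here, this is the first measured exchange in this set that removes a ring nitrogen and brings in a fluorine: the entering group has a ring of carbon only and no hydrogen-bond acceptor, while the leaving group counts one, yet the two compounds stay within the usual scatter of each other. At this position, then, a six-membered aromatic ring with one hetero atom and a fluorine-bearing ring of carbon only can be exchanged without a measurable change in this assay, and no supporting measurement is available to explain the result.

The exchange alters the ring atoms and adds fluorine in a single step. The compounds shown leave the contribution of each change unresolved, and plain phenyl would be the group needed to separate them. Going by these compounds, it also remains open how this position responds to a ring carrying a carboxylic acid or a primary amine.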